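A Third Aryl Group on the Shared Core

This account rests on a few compounds, and the source may have more. Where it says the series, first, only, none or still open, it means among the compounds named here.

In a functional assay on CNE-2 cells (Homo sapiens) for antiproliferative activity, read by sulforhodamine B assay, with a stated time of 48 h (on this read-out lower numbers stand for stronger inhibition and higher numbers for weaker inhibition), compound 1 (`COc1ccc(OC)c(/C=C/C(=O)C(=Cc2ccc(OC)c(OC)c2)C(=O)/C=C/c2cc(OC)ccc2OC)c1`) gives 550 nM, and compound 2 (`COc1ccc(OC)c(/C=C/C(=O)C(=Cc2ccc(O)c(F)c2)C(=O)/C=C/c2cc(OC)ccc2OC)c1`) gives 380 nM. Within the data shown here, these are the only two numbers available, and compound 2 cannot be separated from compound 1 on them. The step that links them, a 1.4-fold lower number from compound 1 to compound 2 (0.16 log units; within the scatter), replaced 3,4-dimethoxyphenyl with 3-fluoro-4-hydroxyphenyl on a double-bonded chain carbon bound to a double-bonded chain carbon.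

Compound 3 (`COc1ccc(OC)c(/C=C/C(=O)C(=Cc2cc(OC)c(O)c(OC)c2)C(=O)/C=C/c2cc(OC)ccc2OC)c1`) differs from compound 2 at that same place: 4-hydroxy-3,5-dimethoxyphenyl in place of 3-fluoro-4-hydroxyphenyl on a double-bonded chain carbon bound to a double-bonded chain carbon. Among the measured compounds shown here, the rest of the structure is unchanged, so the one measured step bears directly on this comparison, although it involves a different pair of groups. For the measured compounds named here, no measured compound carries 4-hydroxy-3,5-dimethoxyphenyl, so the data give no direction for the new change. Going by the values given here, with only that small step from compound 1 to go on (a 1.4-fold lower number from compound 1 to compound 2 (0.16 log units; within the scatter)), no shift beyond the scatter is expected in this assay. The expected change is a 1.1-fold higher number from compound 2 to compound 3 (0.04 log units; within the scatter). For compound 3 the estimated value is 420 nM, within an expected range of 180 nM to 950 nM.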

Compound 3, half-maximal inhibitory concentration: 450 nM
Beside the measured number, compound 3's estimate is 1.1-fold (0.03 log units) below it; the range from low to high includes it.
By their numbers in this assay, from the lowest: compounds 2, 3 and 1 (each within the scatter of the next).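

In this assay, this place now carries three different aryl groups, and exchanging 3-fluoro-4-hydroxyphenyl for 4-hydroxy-3,5-dimethoxyphenyl, with 11 heavy atoms instead of 8 and 3 hydrogen-bond acceptors instead of 1, gives a 1.2-fold higher number from compound 2 to compound 3 (0.07 log units; within the scatter). The exchange of 3,4-dimethoxyphenyl for the same group gives a 1.2-fold lower number from compound 1 to compound 3 (0.09 log units; within the scatter), so the three compounds cannot be separated on this read-out, whether or not the group on the double-bonded chain carbon holds a fluorine or a hydroxy group. No available evidence bears on this result or connects it to any feature of these groups.

From the compounds shown here alone, all three groups are built on a six-membered aromatic ring of carbon only, so it remains open what an amine, a carboxylic acid or a longer chain would do on this double-bonded chain carbon. Going by these compounds, it also remains open whether these three groups would stay this close if the two 2,5-dimethoxyphenyl-bearing chains of the shared core were changed.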